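Swapping nitro for hydroxy on the shared core

This account rests on a few compounds, and the source may have more. Where it says the series, first, only, none or still open, it means among the compounds named here.

Of the compounds shown here, three built on one core have been tested. Compound 1 `O=C1N=C(C2C(=O)c3ccccc3C2=O)CC(c2ccccc2[N+](=O)[O-])N1` gives 35% in a functional assay on the whole organism for inhibition, with Mus musculus as the target, in the writhing test, with a stated time of 15 min, at a dose of 10 mg/kg; a lower number here means less inhibition, a higher number more inhibition at the dose given (going by the name of the read-out). Compound 2 `O=C1N=C(C2C(=O)c3ccccc3C2=O)CC(c2ccccc2)N1` gives 31%, and compound 3 `O=C1N=C(C2C(=O)c3ccccc3C2=O)CC(c2cccc([N+](=O)[O-])c2)N1` gives 36%. The three numbers sit close together: the step of a number 4 percentage points lower from compound 1 to compound 2 (within the scatter) and the step of a number 1 percentage points higher from compound 1 to compound 3 (within the scatter) both stay inside the usual scatter, so compound 1 stands neither apart from nor clearly above either neighbour.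

Compound 4 `O=C1N=C(C2C(=O)c3ccccc3C2=O)CC(c2ccccc2O)N1` differs from compound 1 in one place: hydroxy in place of nitro on an aromatic carbon. Among the measured compounds shown here, the steps that bear on this change are those that remove or add the nitro group, namely a number 4 percentage points lower from compound 1 to compound 2 (within the scatter) and a number 5 percentage points higher from compound 2 to compound 3 (within the scatter); neither moved the read-out beyond the scatter. For the measured compounds named here, no measured compound carries a hydroxy group, so the effect of that group itself is unknown. Compound 4 is therefore expected to show a step of a number 2 percentage points lower from compound 1 to compound 4 (within the scatter), that is, no change beyond the scatter. The estimate for compound 4 is 33%, with a range from 20% to 46%.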

Compound 4, a percentage reported as inhibition, in the whole organism at one dose (the size of the read-out at that dose, not a potency): 37%
For compound 4 the middle estimate is 4 percentage points below the measured one; the range from low to high includes it.
By their numbers in this assay, from the lowest: compounds 2, 1, 3 and 4 (each within the scatter of the next).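

Hydroxy in place of nitro on this aromatic carbon, ortho to a large group, gives a number 2 percentage points higher from compound 1 to compound 4 (within the scatter) in this assay, so a group that differs this much from nitro in its atoms still leaves the read-out inside the scatter. The other two comparisons agree: the change of 3-nitrophenyl to 2-hydroxyphenyl gives a number 1 percentage points higher from compound 3 to compound 4 (within the scatter) and the addition of hydroxy in place of hydrogen gives a number 6 percentage points higher from compound 2 to compound 4 (within the scatter), so all four compounds now lie within the scatter of the next, and neither group separates from hydrogen at this position. Nothing measured here explains why these numbers lie so close together.

As far as these compounds go, whether an amine, a methoxy group or a carboxylic acid on this aromatic carbon would also stay within the scatter remains open. Also open, from the compounds shown here alone, is whether hydroxy on another carbon of the ring would behave as it does here.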